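Moving the methyl on the aryl group of compound 2

The source may report more compounds than this note shows. Statements on the series, on what has been measured and on what is new or still open speak of the compounds shown alone.

Measured so far: compound 1 `Cc1nc(-c2cccs2)sc1COc1ccc2c(c1)OCC2CC(=O)O` with 35.2%; compound 2 `Cc1ccccc1-c1nc(C)c(COc2ccc3c(c2)OCC3CC(=O)O)s1` with 10.7%.

In a functional assay on CHO cells for agonist activity at Free fatty acid receptor 1 (Homo sapiens), read by FLIPR and calcium flux, tested at 100 nM (a higher number here means a stronger effect of the compound at the concentration tested, a lower number a weaker effect), compound 2 stands lowest of the two numbers shown; its nearest neighbour, compound 1, is set apart by a number 24.5 percentage points lower from compound 1 to compound 2 (beyond the scatter). Compound 3 `Cc1ccc(-c2nc(C)c(COc3ccc4c(c3)OCC4CC(=O)O)s2)cc1` differs from compound 2 by 4-methylphenyl in place of 2-methylphenyl on an aromatic carbon. Among the compounds with values here, no measured step exchanges one methylphenyl for another, so the one step seen, which swapped a thiophen-2-yl for the aryl group, gives only an indirect hint. Compound 3 is therefore expected near 20%, within 5% to 45%, an estimated change of a number 9.3 percentage points higher from compound 2 to compound 3 (within the scatter).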

Compound 3, a percentage reported as activity, at one concentration (the size of the read-out at that concentration, not a potency): 54.9%
Compound 3: middle estimate off by 34.9 percentage points, on the low side, outside the stated range (above it).
By their numbers in this assay, from the lowest: compound 2; then compound 1; then compound 3.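

In this assay, the position of the methyl on the phenyl group proves decisive: with the atoms unchanged, the move gives a large step (a number 44.2 percentage points higher from compound 2 to compound 3 (beyond the scatter)). Replacing thiophen-2-yl with an aryl group therefore need not lower the read-out, since 4-methylphenyl gives a rise (a number 19.7 percentage points higher from compound 1 to compound 3 (beyond the scatter)), whereas 2-methylphenyl gave a fall (a number 24.5 percentage points lower from compound 1 to compound 2 (beyond the scatter)). Nothing available accounts for this difference. Still open, on these data alone, is whether an ethyl or methoxy group in place of the methyl of the 4-methylphenyl group would keep this gain. The single tested concentration also leaves the potency of compound 3 open.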